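From phenyl to benzyl on a saturated chain carbon

This account rests on a few compounds, and the source may have more. Where it says the series, first, only, none or still open, it means among the compounds named here.

In a physicochemical assay for solubility, in phosphate buffer, measured as kinetic solubility (on this read-out higher numbers stand for higher solubility and lower numbers for lower solubility), compound 1 `CCC(CC)C(/C=C1\OC(=O)NC1=O)c1ccc(-c2ccc3cccc(F)c3c2)[nH]c1=O` gives 33700 nM and compound 2 `O=C1NC(=O)/C(=C/C(c2ccccc2)c2ccc(-c3ccc4cccc(F)c4c3)[nH]c2=O)O1` gives 32800 nM on the same shared core. Among the measured compounds shown here, these two numbers lie within the scatter of each other, so compound 2 stands level with the only other measured compound. For the measured compounds named here, the single measured step is a 1.0-fold lower number from compound 1 to compound 2 (0.01 log units; within the scatter) with phenyl in place of pentan-3-yl on a saturated chain carbon bound to an aromatic carbon and a double-bonded chain carbon. Compound 3 `O=C1NC(=O)/C(=C/C(Cc2ccccc2)c2ccc(-c3ccc4cccc(F)c4c3)[nH]c2=O)O1` has not yet been measured and differs from compound 2 at that same carbon: benzyl in place of phenyl on a saturated chain carbon bound to an aromatic carbon and a double-bonded chain carbon with benzyl in place of phenyl. Going by the values given here, no measured step involves benzyl, so the expectation rests on that one pair alone and is correspondingly loose. With compound 2 reached through a 1.0-fold lower number from compound 1 to compound 2 (0.01 log units; within the scatter) at this carbon, no change beyond the scatter is expected in this assay for the new swap. The expected step is a 1.1-fold lower number from compound 2 to compound 3 (0.04 log units; within the scatter) and no direction is favoured. For compound 3 the estimated value is 30000 nM with an expected range from 13000 nM to 60000 nM in this read-out.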

Compound 3, solubility: 9100 nM
The estimate for compound 3 lay 3.3-fold (0.52 log units) above the measured number; the whole stated range lies above it.
By their numbers in this assay, from the lowest: compound 3; then compounds 2 and 1 (each within the scatter of the next).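

In this assay, the saturated chain carbon bound to an aromatic carbon and a double-bonded chain carbon now shows a step beyond the scatter: benzyl in place of phenyl gives a 3.6-fold lower number from compound 2 to compound 3 (0.56 log units; beyond the scatter), and benzyl in place of pentan-3-yl gives a 3.7-fold lower number from compound 1 to compound 3 (0.57 log units; beyond the scatter). Phenyl and pentan-3-yl had stood level, so the earlier pair alone showed no sensitivity to the group at this carbon, whereas benzyl, which carries the same six-membered aromatic ring of carbon only as phenyl, stands apart from both, and so the ring alone does not set the number here. Nothing available explains this difference.

The compounds shown leave open whether a longer chain carrying the same ring, such as phenethyl, would stand level with compound 3 or apart from it. They also leave open whether an amine or a carboxylic acid on the ring of the benzyl group would bring the number back to the level of compound 1 and compound 2.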